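A few compounds are considered here, and "the series" means these few. Any claim that something is new, unique, unknown or untested is made for them only; others in the source may bear on it.

Measured compounds:
compound 1, `CS/C(=N\C(=O)c1sccc1Cl)NC(=O)c1sccc1Cl`, 10300 nM
compound 2, `C[Se]/C(=N\C(=O)c1cccs1)NC(=O)c1cccs1`, 3.4 nM

Of the compounds shown here, two have so far been measured in a functional assay on MCF7 cells (Homo sapiens) for cytotoxicity, read by MTT assay, with a stated time of 72 h; a higher number here means a weaker inhibitor of growth, a lower number a stronger inhibitor of growth. Compound 1, `CS/C(=N\C(=O)c1sccc1Cl)NC(=O)c1sccc1Cl`, gives 10300 nM. Compound 2, `C[Se]/C(=N\C(=O)c1cccs1)NC(=O)c1cccs1`, gives 3.4 nM, the lower of the two numbers, and the gap between compound 1 and compound 2 lies far beyond the usual scatter of the measurement. Compound 3, `O=C(/N=C(/NC(=O)c1cccs1)[Se]Cc1ccccc1)c1cccs1`, has not yet been measured in this assay. It differs from compound 2 by phenyl in place of hydrogen on a saturated chain carbon bound to a selenium atom; cut one bond further out, the change reads methyl to benzyl. For the measured compounds named here, no pair of measured compounds differing in one place is available to show what a change of this kind does here. The step is therefore expected to be modest, most likely a small loss of growth inhibition that may fall within the scatter, and is estimated at a 2.9-fold higher number from compound 2 to compound 3 (0.47 log units; beyond the scatter). For compound 3 the estimate in this assay is 10 nM, expected to lie between 2 nM and 60 nM.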

Compound 3, concentration for 50% growth inhibition: 72500 nM
Compound 3: middle estimate off by 7300-fold (3.86 log units), on the low side; measured number outside the range, above it.
By their numbers in this assay, from the lowest: compound 2; then compound 1; then compound 3.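

In this assay, the saturated chain carbon bound to a selenium atom proves to be a highly sensitive place: phenyl in place of hydrogen there, which reads as methyl to benzyl, gives a 21000-fold higher number from compound 2 to compound 3 (4.33 log units; beyond the scatter). This single change takes the series from its lowest number to its highest, so a substituent on this carbon can decide nearly all of the growth inhibition seen with compound 2. Nothing available accounts for the size of this step.

As far as these compounds go, it remains open whether the loss belongs to the phenyl ring itself or would also follow from a simple alkyl group, such as an ethyl group or a longer chain in place of the benzyl. From the compounds shown here alone, whether a polar group such as an amine or a carboxylic acid on this carbon would be tolerated also remains open.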